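This account rests on a few compounds, and the source may have more. Where it says the series, first, only, none or still open, it means among the compounds named here.

Measured so far in a functional assay on SW-620 cells (Homo sapiens); a lower number here means a stronger inhibitor of growth, a higher number a weaker inhibitor of growth:
Compound 1 `O=S(=O)(/C=C/c1ccc(Cl)cc1)Cc1ccc(Nc2ncnc3ccccc23)cc1` gives 77000 nM
Compound 2 `O=S(=O)(/C=C/c1ccc(C(F)(F)F)cc1F)Cc1ccc(Nc2ncnc3ccccc23)cc1` gives 100000 nM
Compound 3 `O=S(=O)(/C=C/c1ccc(Cl)cc1)Cc1ccc(Nc2ncnc3ccc(Br)cc23)cc1` gives 45000 nM

Compound 3 at 45000 nM lies within the usual scatter of compound 1, so those two cannot be told apart. Its number is smaller than that of compound 2 at 100000 nM by a gap beyond the scatter. All three remain weak growth inhibitors on this scale.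

Compound 4 `O=S(=O)(/C=C/c1ccc(C(F)(F)F)cc1F)Cc1ccc(Nc2ncnc3ccc(Br)cc23)cc1` differs from compound 3 at one place, with 2-fluoro-4-(trifluoromethyl)phenyl in place of 4-chlorophenyl on a double-bonded chain carbon bound to a double-bonded chain carbon. The same swap has been measured once, without the bromo group, and it gave a 1.3-fold higher number from compound 1 to compound 2 (0.11 log units; within the scatter) as its result. The bromo group itself gave a 1.7-fold lower number from compound 1 to compound 3 (0.23 log units; within the scatter) as its result. As far as these compounds go, whether the two changes simply add up is untested, since only these compounds are available. The swap alone therefore points to no step beyond the scatter in this assay, with a slight rise at most. The expected step is a 1.3-fold higher number from compound 3 to compound 4 (0.11 log units; within the scatter) by this estimate. For compound 4 the estimated value is 58000 nM with an expected range of 30000 nM to 110000 nM in this measurement.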

Compound 4, concentration for 50% growth inhibition: 55000 nM
Compound 4: the middle estimate sits 1.1-fold (0.02 log units) above what was measured, and the stated range covers the measured number.
By their numbers in this assay, from the lowest: compounds 3, 4, 1 and 2 (each within the scatter of the next, the first and the last beyond it).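

In this assay, among these compounds, the swap to 2-fluoro-4-(trifluoromethyl)phenyl can now be read on a second core, the one carrying the bromo group, and a 1.2-fold higher number from compound 3 to compound 4 (0.09 log units; within the scatter) shows that it stays as small there as it was without that group: the same change on two cores in this assay, a 1.3-fold higher number (0.11 log units; within the scatter) from compound 1 to compound 2 and a 1.2-fold higher number (0.09 log units; within the scatter) from compound 3 to compound 4, 1.1-fold (0.03 log units) apart, within the scatter of two such steps. The bromo group can likewise be read a second time, now with 2-fluoro-4-(trifluoromethyl)phenyl in place of 4-chlorophenyl, and a 1.8-fold lower number from compound 2 to compound 4 (0.26 log units; within the scatter) agrees with its first reading: the same change on two cores in this assay, a 1.7-fold lower number (0.23 log units; within the scatter) from compound 1 to compound 3 and a 1.8-fold lower number (0.26 log units; within the scatter) from compound 2 to compound 4, 1.1-fold (0.03 log units) apart, within the scatter of two such steps. Across these four compounds, then, neither change alters the size of the other, and none of the four goes against this, although every one of these steps lies within the scatter, so the agreement is between small steps and shows no clear effect of either change.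

As far as these compounds go, both groups at this place are halogen-bearing phenyl rings, so it remains open whether a phenyl ring carrying an amine or a carboxylic acid would give a step beyond the scatter. From the compounds shown here alone, it is also open whether an amine or a longer chain in place of the bromo group would move the number any further than bromo does.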